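The source may report more compounds than this note shows. Statements on the series, on what has been measured and on what is new or still open speak of the compounds shown alone.

Measured compounds:
compound 1 `C/C=C1/[C@H](O[C@@H]2O[C@H](CO)[C@@H](O)[C@H](O)[C@H]2O)OC=C(C(=O)OC)[C@H]1CC(=O)OCCc1ccc(O)cc1` — > 20000 nM
compound 2 `C=CCOC(=O)C[C@@H]1C(C(=O)OC)=CO[C@@H](O[C@@H]2O[C@H](COC(C)=O)[C@@H](OC(C)=O)[C@H](OC(C)=O)[C@H]2OC(C)=O)/C1=C/C` — > 20000 nM

In a functional assay on SK-BR-3 cells (Homo sapiens) for antiproliferative activity, read by MTT assay, with a stated time of 72 h (a higher number here means a weaker inhibitor, a lower number a stronger inhibitor), compound 1 gives > 20000 nM, and this is a limit of the assay rather than a measured number. In this assay compound 2 gives > 20000 nM, also a limit. Compound 1 thus stands at the weak end of what the assay can report, at the limit of > 20000 nM in this assay, at which 2 of the 2 values shown sit, and no finished number separates it from compound 2.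

Compound 3 `C/C=C1/[C@H](O[C@@H]2O[C@H](CO)[C@@H](O)[C@H](O)[C@H]2O)OC=C(C(=O)OC)[C@H]1CC(=O)OCCC` has not yet been tested. It differs from compound 1 in one place: methyl in place of 4-hydroxyphenyl on a saturated chain carbon, two bonds along the chain from an oxygen next to a carbonyl group. Within the data shown here, no pair of measured compounds differing in a single place exists here, so the size of this kind of step in this assay is not known from these data. With both measured compounds at the limit, compound 3 is expected to give about 40000 nM, within a range from 10000 nM to 150000 nM. The expected step that the limit leaves unreadable from compound 1 to compound 3 is therefore essentially none beyond the scatter, and another limit is the most likely outcome.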

Compound 3, half-maximal inhibitory concentration: > 15000 nM
Compound 3 gave a limit, no number; the forecaster's own chance of this, stated with the estimate: 85%; the middle value is on the limit's open side.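

In this assay, among these compounds, compound 1 and compound 3 both give only limits rather than numbers, and no step between them can be read. The compounds shown leave open whether methyl in place of 4-hydroxyphenyl changes the activity at all, and which change to the shared core would give a finished number.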